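A few compounds are considered here, and "the series" means these few. Any claim that something is new, unique, unknown or untested is made for them only; others in the source may bear on it.

Compound 1 `CNC(=O)c1ccc(NCc2cncn2Cc2ccc(-c3ccccc3)cc2)cc1-c1ccccc1`: > 1000 nM, a limit.
Compound 2 `CCOC(=O)c1ccc(NCc2cncn2Cc2ccc(-c3ccccc3)cc2)cc1-c1ccccc1`: > 10000 nM, a limit.
Compound 3 `CCCC(=O)c1ccc(NCc2cncn2Cc2ccc(-c3ccccc3)cc2)cc1-c1ccccc1`: > 10000 nM, a limit.

All three entries come from a toxicity assay on NIH3T3 cells (Mus musculus) for cytotoxicity, read by resazurin assay (on this read-out lower numbers stand for an effect already at smaller amounts and higher numbers for an effect only at larger amounts of compound), so none of these compounds has an exact value and they cannot be ranked. Compound 3 sits at the limit of > 10000 nM in this assay, at which 2 of the 3 values shown sit. Compound 1 sits at the limit of > 1000 nM in this assay, at which 1 of the 3 values shown sits.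

The next compound is compound 4 `c1ccc(-c2ccc(Cn3cncc3CNc3ccc(-c4cc5ccccc5o4)c(-c4ccccc4)c3)cc2)cc1`. Its change from compound 3 is 1-benzofuran-2-yl in place of propylcarbonyl on an aromatic carbon. In words, 1-benzofuran-2-yl takes the place of propylcarbonyl on an aromatic carbon, ortho to a phenyl group and para to a large group.

For the measured compounds named here, two measured steps bear most directly on this site: a step that the two limits leave unreadable from compound 1 to compound 3 and a step that the two limits leave unreadable from compound 2 to compound 3. Both changes are made on the carbonyl carbon, and neither removes the whole carbonyl group as this change does. Neither step has a readable size, so they give no measured size or direction to carry over to compound 4.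

The expected change is therefore none that can be stated with confidence, and it is estimated as a step that the limit leaves unreadable from compound 3 to compound 4. The expectation starts from compound 3 at > 10000 nM, a limit. For compound 4 the estimated value is 12000 nM. The expected range runs from 3000 nM to 40000 nM.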

Compound 4, half-maximal effective concentration: > 10000 nM
Compound 4: a limit, no number; the forecaster's own chance of this, stated with the estimate: 75%; the middle value is on the limit's open side.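

In this assay compound 4 gives > 10000 nM, a limit and not a number. Compounds 1, 2 and 3 also stand only as limits, so the steps from each of them to compound 4 cannot be read. The compounds shown leave open what exact value any of the four would have, and whether changing this group shifts it.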